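A few compounds are considered here, and "the series" means these few. Any claim that something is new, unique, unknown or untested is made for them only; others in the source may bear on it.

Three close relatives share a common core, differing only in the group carried on a five-membered aromatic ring with 4 nitrogen. Compound 1 `CCCCCCCCc1ccc(OCC(=O)Cn2nnc(-c3ccccc3Cl)n2)cc1` and compound 2 `CCCCCCCCc1ccc(OCC(=O)Cn2nnc(-c3cccs3)n2)cc1` carry aryl groups there, and in an assay on microsomes from brain for inhibition of Fatty-acid amide hydrolase 1 (Rattus norvegicus), read by fluorescence and HPLC, with a stated time of 60 min (a lower number here means a stronger inhibitor, a higher number a weaker inhibitor), compound 1 gives 32 nM while compound 2 gives 32 nM; the step of no change at the digits printed from compound 1 to compound 2 (within the scatter) shows that exchanging one aryl for another leaves the result where it was. Compound 3 `CCCCCCCCc1ccc(OCC(=O)Cn2nnnc2-c2ccccc2)cc1` carries a phenyl on an aromatic carbon and stands highest of the three, with 71 nM in this assay, a gap beyond the scatter from both of its neighbours.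

Compound 4 `CCCCCCCCc1ccc(OCC(=O)Cn2nnnc2C(=O)OC)cc1` takes the step from compound 3 described as methoxycarbonyl in place of phenyl on an aromatic carbon. Going by the values given here, no measured step here exchanges an aromatic ring for a small ester, so the only step on record, from one aryl to another, does not bear directly on this change; it shows only that the aromatic substituent can be varied without cost. Taking away the ring altogether is a larger change, and compound 4 is expected to sit somewhat weaker than compound 3, a step estimated as a 2.3-fold higher number from compound 3 to compound 4 (0.35 log units; beyond the scatter). The estimate for compound 4 in this assay is therefore 160 nM, expected to fall between 50 nM and 600 nM.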

Compound 4, half-maximal inhibitory concentration: 1000 nM
Compound 4: middle estimate off by 6.3-fold (0.80 log units), on the low side; measured number above the stated range.
By their numbers in this assay, from the lowest: compounds 1 and 2 (each within the scatter of the next); then compound 3; then compound 4.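

In this assay, replacing the phenyl with methoxycarbonyl on the aromatic carbon gives a 14-fold higher number from compound 3 to compound 4 (1.15 log units; beyond the scatter), a large step and the first in this set to take an aromatic ring away from the five-membered aromatic ring with 4 nitrogen. Going by these compounds alone, the only earlier step, no change at the digits printed from compound 1 to compound 2 (within the scatter), exchanged one aromatic ring for another, so the freedom it suggested does not extend to this change: an open-chain ester with no ring, fewer heavy atoms and two hydrogen-bond acceptors is far from equivalent to phenyl here. No measurement offered here explains why the number rises so sharply.

Within the data shown here, the single step changes several things at once, so it cannot separate the loss of the phenyl ring from the arrival of the ester. A methyl group on the same aromatic carbon would give a measurement with the ring gone and no ester present. Among these compounds, a carboxylic acid, a primary amide or a benzyl group on that carbon would show whether the steep rise is seen only with the methoxycarbonyl group or with any group that is not an aromatic ring.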